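Inverting Two Ring Stereocentres in Compound 2

This account rests on a few compounds, and the source may have more. Where it says the series, first, only, none or still open, it means among the compounds named here.

In a functional assay on PANC-1 cells (Homo sapiens) for antiproliferative activity (on this read-out lower numbers stand for stronger inhibition and higher numbers for weaker inhibition), compound 2 (`CC[C@H](C)[C@H]1C(=O)N[C@H](Cc2ccc(O)c(Br)c2)C(=O)N[C@@H](C(C)(C)O)C(=O)O[C@H](c2ccccc2)[C@H](C)/C=C/C=C(\C)[C@H](OC)C[C@@H]2O[C@@]2(C)C(=O)N1C`) gives 9.61 nM as its half-maximal inhibitory concentration. On the same read-out compound 1 (`CC[C@H](C)[C@H]1C(=O)N[C@H](Cc2ccc(O)c(Br)c2)C(=O)N[C@@H](C(C)(C)O)C(=O)O[C@H](c2ccccc2)[C@H](C)/C=C/C=C(\C)[C@H](OC)C/C=C(\C)C(=O)N1C`) gives 11.4 nM and compound 3 (`CC[C@H](C)[C@H]1C(=O)N[C@H](Cc2ccc(O)c(Br)c2)C(=O)N[C@@H](C(C)C)C(=O)O[C@H](c2ccccc2)[C@H](C)/C=C/C=C(\C)[C@H](OC)C[C@@H]2O[C@@]2(C)C(=O)N1C`) gives 15.7 nM in the same narrow band. Both lie within the scatter of compound 2, so no real gap sets it apart from either.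

Compound 4 (`CC[C@H](C)[C@H]1C(=O)N[C@H](Cc2ccc(O)c(Br)c2)C(=O)N[C@@H](C(C)(C)O)C(=O)O[C@H](c2ccccc2)[C@H](C)/C=C/C=C(\C)[C@H](OC)C[C@H]2O[C@]2(C)C(=O)N1C`) differs from compound 2 in configuration only (the two compounds have the same atoms and bonds and differ only in configuration as drawn: 2 of 11 stereo elements differ; a stereocentre at a saturated ring carbon is drawn S in compound 2 and R in compound 4; a stereocentre at a saturated ring carbon is drawn R in compound 2 and S in compound 4). Going by the values given here, no measured step inverts a stereocentre, so the evidence is indirect. Replacing hydroxy with hydrogen gives a 1.6-fold higher number from compound 2 to compound 3 (0.21 log units; within the scatter) and so stays within the scatter, but it happens at a different place in the molecule. Compound 1, which lacks the ring holding the two inverted centres, gives 11.4 nM and so also stays within the scatter of compound 2. Among the compounds with values here, neither comparison tests what the inverted arrangement does, and the data hold no pair of stereoisomers.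

A modest rise in the number is therefore expected in this assay, with wide uncertainty in both directions. The expected change is a 3.1-fold higher number from compound 2 to compound 4 (0.49 log units; beyond the scatter) as estimated here. For compound 4 the estimate is 30 nM (expected range 8 nM to 200 nM).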

Compound 4, half-maximal inhibitory concentration: > 200 nM
Compound 4 gave a limit, no number (the forecaster's own chance of this, stated with the estimate: 2%); middle value at least 6.6-fold (0.82 log units) away from the limit.
By their numbers in this assay, from the lowest: compounds 2, 1 and 3 (each within the scatter of the next). At a limit, above all of these: compound 4.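

In this assay compound 4 gives > 200 nM, and this is a limit of the assay, not a number. The step is an at least 20-fold higher number from compound 2 to compound 4 (1.31 log units; beyond the scatter), the only step among these compounds printed as beyond the scatter, whereas a 1.6-fold higher number from compound 2 to compound 3 (0.21 log units; within the scatter) stays within it, and compound 1, which lacks the ring holding the two centres altogether, gives 11.4 nM. So the arrangement at these two saturated ring carbons matters in a way the earlier compounds did not reveal, and the large step can be assigned to configuration alone, because no atom or bond changes between the pair: the fact that compounds 2 and 4 differ only in the configuration as drawn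

From the compounds shown here alone, how far compound 4 lies past its limit stays open, as does whether inverting just one of the two ring stereocentres would be enough to give such a step. Also open, going by these compounds, is how an amine or a fluorine on these saturated ring carbons would fare in either configuration, and whether the inverted arrangement gives the same step in the setting of compound 3, with hydrogen in place of hydroxy.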